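A few compounds are considered here, and "the series" means these few. Any claim that something is new, unique, unknown or untested is made for them only; others in the source may bear on it.

Measured so far:
- compound 1, `CC(=O)CCCCC(=O)N1CCN(c2nccc(Oc3cccc(C)c3)n2)CC1`: 3%
- compound 2, `Cc1cccc(N(C)c2cc(Nc3cccc(C(=O)N4CCCC5CCCCC54)c3)ncn2)c1`: 12%

Both compounds were tested in an assay on isolated protein for inhibition of ribosomal protein S6 kinase beta-1 (Homo sapiens), read by HTRF, tested at 10 uM; on this read-out lower numbers stand for less inhibition and higher numbers for more inhibition at the one concentration tested (going by the name of the read-out). In this assay compound 1 gives 3% and compound 2 gives 12%. Of the two numbers, that of compound 2 is the higher, yet its gap to compound 1 lies within the usual scatter of repeated measurements, so the two compounds cannot be told apart on this read-out; both sit near the bottom of the scale.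

Compound 3, `Cc1cccc(N(C)c2cc(Nc3cccc(C(=O)N(CC(C)C)CC(C)C)c3)ncn2)c1`, has not yet been measured. It differs from compound 2 in a single place: a group of 9 heavy atoms (8 carbon, 1 nitrogen; no ring) in place of a group of 10 heavy atoms (9 carbon, 1 nitrogen; one six-membered non-aromatic ring of carbon only, one six-membered non-aromatic ring with 1 hetero atom), on a carbonyl carbon. The rest of the molecule is shared.

Going by the values given here, no measured pair shows what such an exchange on a carbonyl carbon does in this assay, so there is nothing to lean on apart from the low numbers of compound 1 and compound 2 themselves. The expectation is therefore a step of about a number 2 percentage points lower from compound 2 to compound 3 (within the scatter), meaning no change beyond the scatter. Compound 3 is expected to give roughly 10%, with a plausible range from 0% to 25%.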

Compound 3, a percentage reported as inhibition, at one concentration (the size of the read-out at that concentration, not a potency): 11%
The estimate for compound 3 lay 1 percentage points below the measured number, and the stated range covers the measured number.
By their numbers in this assay, from the lowest: compounds 1, 3 and 2 (each within the scatter of the next).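

Swapping the ring-bearing group for diisobutylamino on this carbonyl carbon gives a number 1 percentage points lower from compound 2 to compound 3 (within the scatter) in this assay and so leaves the two compounds indistinguishable on this read-out. Going by these compounds alone, this is the first measured exchange at this place, and it shows that a group with no ring and one with two six-membered rings can stand on the carbonyl carbon without the read-out telling them apart. Both numbers sit near the bottom of the scale, however, so this pair says little about how much this position can matter when a compound inhibits more strongly. Nothing measured here explains why the two groups read alike.

As far as these compounds go, what a much smaller group such as dimethylamino, or a group carrying a basic amine or a carboxylic acid, would do on the same carbonyl carbon remains open. Also open, from the compounds shown here alone, is whether any change at this place can lift the number clearly beyond the scatter, and whether the exchange seen here would read the same way on a more strongly inhibiting compound.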